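The source may hold more compounds than are shown below. What is called first, only, known or untested is meant among the compounds shown, and "the series" means these compounds.

Measured so far:
- compound 1, `O=C(COc1ccc2c(=O)c(-c3ccccc3)coc2c1)Nc1ccc(F)cc1`: 550 nM
- compound 2, `COc1ccc(NC(=O)COc2ccc3c(=O)c(-c4ccccc4)coc3c2)cc1`: 6700 nM

Both compounds share one core and differ only in the group at the far end of the anilide. In a functional assay on NPC-TW01 cells (Homo sapiens) for antiproliferative activity, read by MTT assay, with a stated time of 72 h (on this read-out higher numbers stand for weaker inhibition of growth and lower numbers for stronger inhibition of growth), compound 1 gives 550 nM, while compound 2 gives 6700 nM. That single step, a 12-fold higher number from compound 1 to compound 2 (1.09 log units; beyond the scatter), is the only one recorded, and it leaves compound 2 with the highest number of the two, so compound 2 is the weaker of the pair in this assay.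

Compound 3, `O=C(COc1ccc2c(=O)c(-c3ccccc3)coc2c1)Nc1ccc(-c2ccccc2)cc1`, carries the change (phenyl in place of methoxy on an aromatic carbon). Within the data shown here, the one measured step bears on it only indirectly: it shows that swapping the group at this position can shift the number by a large amount, but phenyl resembles neither fluoro nor methoxy, so the direction is open. A phenyl here might recover part of what compound 2 lost, or might not; the expected step is therefore modest and uncertain, roughly a 2.2-fold lower number from compound 2 to compound 3 (0.35 log units; beyond the scatter). Compound 3 is expected to give about 3000 nM, within a wide range from 600 nM to 15000 nM.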

Compound 3, concentration for 50% growth inhibition: 1750 nM
Estimate against measurement, compound 3: 1.7-fold (0.23 log units) above; the measured number falls inside the stated range.
By their numbers in this assay, from the lowest: compound 1; then compound 3; then compound 2.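

Replacing methoxy with phenyl gives a 3.8-fold lower number from compound 2 to compound 3 (0.58 log units; beyond the scatter) in this assay and so shows that a group with a whole aromatic ring can sit at this position without raising the number further. Size alone therefore does not set the order here, since phenyl has more heavy atoms than methoxy and yet gives the lower number. Phenyl still does not match fluoro, as replacing fluoro with phenyl gives a 3.2-fold higher number from compound 1 to compound 3 (0.50 log units; beyond the scatter) and leaves compound 1 with the lowest number of the three, but nothing shown explains why the three groups fall in this order.

The compounds shown leave open where other groups on this same aromatic carbon would fall in that order, such as a chlorine atom, an amine, a carboxylic acid or a longer chain ending in a phenyl ring. They also leave open whether fluoro, phenyl and methoxy would keep the same order if the shared core were changed or if the group were placed elsewhere on the ring.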